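Ring closure of the amino alcohol arm on the alkyne

The source may report more compounds than this note shows. Statements on the series, on what has been measured and on what is new or still open speak of the compounds shown alone.

In a functional assay on SW480 cells (Homo sapiens) for inhibition (a lower number here means a stronger inhibitor, a higher number a weaker inhibitor), compound 3 `COc1cc[nH]c1/C=C1\C(=O)Nc2ccc(F)c(C#C[C@H](N)CO)c21` gives 270 nM. Compound 1 `COc1cc[nH]c1/C=C1\C(=O)Nc2ccc(F)c(C#C[C@H](C)O)c21` gives 400 nM and compound 2 `COc1cc[nH]c1/C=C1\C(=O)Nc2ccc(F)c(C#CC(O)CN)c21` gives 110 nM. Among these three numbers compound 3 stands second highest: the nearer neighbour is a 1.5-fold lower number from compound 1 to compound 3 (0.17 log units; within the scatter), the further one a 2.5-fold higher number from compound 2 to compound 3 (0.39 log units; beyond the scatter).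

Compound 4 `COc1cc[nH]c1/C=C1\C(=O)Nc2ccc(F)c(C#C[C@@H]3C[C@H](O)CN3)c21` has not yet been measured in this assay. It differs from compound 3 as follows: 4-hydroxypyrrolidin-2-yl in place of 1-amino-2-hydroxyethyl on a triple-bonded carbon. Among the measured compounds shown here, no measured step closes an open arm into a ring; the steps that bear on the change are those that rearrange the substituent on the same triple-bonded carbon, namely a 3.6-fold lower number from compound 1 to compound 2 (0.56 log units; beyond the scatter), a 1.5-fold lower number from compound 1 to compound 3 (0.17 log units; within the scatter) and a 2.5-fold higher number from compound 2 to compound 3 (0.39 log units; beyond the scatter). For the measured compounds named here, each of these is modest or within the scatter, so swapping the arrangement of the amino and hydroxy groups on this arm has shifted the number only a little so far, and the difference to compound 4 keeps the same donor and acceptor count. For compound 4 the expected step is therefore small, a 1.2-fold lower number from compound 3 to compound 4 (0.09 log units; within the scatter), within the scatter. Compound 4 is estimated at 220 nM, with a range from 80 nM to 600 nM.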

Compound 4, half-maximal inhibitory concentration: 90 nM
Estimate against measurement, compound 4: 2.4-fold (0.39 log units) above; the range from low to high includes it.
By their numbers in this assay, from the lowest: compounds 4 and 2 (each within the scatter of the next); then compounds 3 and 1 (each within the scatter of the next).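

In (this assay), the first ring on this triple-bonded carbon is tolerated: replacing 1-amino-2-hydroxyethyl with 4-hydroxypyrrolidin-2-yl gives (a 3.0-fold lower number from compound 3 to compound 4 (0.48 log units; beyond the scatter)), with the counts of hydrogen-bond donors and acceptors unchanged, so the number can move at this position without any change in those counts. Among the compounds shown here, the ring does not separate from the best open arm, since 2-amino-1-hydroxyethyl and 4-hydroxypyrrolidin-2-yl differ only by (a 1.2-fold lower number from compound 2 to compound 4 (0.09 log units; within the scatter)), while the step from the simple 1-hydroxyethyl arm is (a 4.4-fold lower number from compound 1 to compound 4 (0.65 log units; beyond the scatter)), the largest so far. No measurement is available that accounts for these steps.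

A plain pyrrolidin-2-yl, a piperidin-2-yl or an N-methyl-4-hydroxypyrrolidin-2-yl would be needed to tell whether the hydroxy group, the ring size or the free ring nitrogen matters to the number. The other stereoisomers of 4-hydroxypyrrolidin-2-yl also remain open, so the compounds shown do not say whether the two defined stereocentres of the ring matter.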